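Butylsulfanyl in Place of Pentyloxy on a Splenocyte Activator

The source may report more compounds than this note shows. Statements on the series, on what has been measured and on what is new or still open speak of the compounds shown alone.

Compound 1 `CCCCCOc1nc(N)c2nc(O)n(Cc3ccccc3)c2n1`: 0.01 uM
Compound 2 `Cc1ccc(Cn2c(O)nc3c(N)ncnc32)cc1`: 10 uM
Compound 3 `Nc1ncnc2c1nc(I)n2Cc1ccccc1`: the assay reports only a limit, > 10 uM

Three compounds sharing one core were tested in a functional assay (spleen, spleen) for activation, with Mus musculus as the target; on this read-out higher numbers stand for an effect only at larger amounts of compound and lower numbers for an effect already at smaller amounts. Compound 1 gives 0.01 uM, the lowest of the two numbers obtained. The nearest number belongs to compound 2 at 10 uM, a gap far beyond the scatter of repeated measurements. For compound 3 the assay gives only a limit, > 10 uM; that compound sits at the limit of > 10 uM in this assay, at which 1 of the 3 values shown sits.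

Compound 4 `CCCCSc1nc(N)c2nc(O)n(Cc3ccccc3)c2n1` has not yet been measured in this assay. It differs from compound 1 in one place: butylsulfanyl in place of pentyloxy on an aromatic carbon. No pair of measured compounds differs in this way, so the size of the step cannot be read from the numbers shown. With a chain of comparable length kept at the same place and only the linking atom and one carbon exchanged, the step from compound 1 to compound 4 is expected to be small, close to the scatter, and its direction is uncertain; the expectation is a 3.0-fold higher number from compound 1 to compound 4 (0.48 log units; beyond the scatter). On that basis compound 4 is estimated at 0.03 uM in this assay, within a range from 0.003 uM to 0.3 uM.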

Compound 4, minimum effective concentration: 0.01 uM
For compound 4 the middle estimate is 3.0-fold (0.48 log units) above the measured one; the measured number falls inside the stated range.
By their numbers in this assay, from the lowest: compounds 1 and 4 (each within the scatter of the next); then compound 2.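

In this assay, the exchange of pentyloxy for butylsulfanyl on the aromatic carbon between two ring nitrogen atoms gives no change at the digits printed from compound 1 to compound 4 (within the scatter). Until this result, compound 1 was the only compound shown with a chain at this place, so the numbers could not tell whether this position would accept any change to that chain; compound 4 shows that it accepts a sulfur link in place of the oxygen link, together with a butyl rather than a pentyl chain, with no loss that can be read in this read-out. Nothing among the data shown accounts for this tolerance, and the two exchanged groups are described here only by their names and atom counts.

Going by these compounds, whether a butylamino group, with a nitrogen as the linking atom, or a longer chain such as octyloxy on the same aromatic carbon would keep this number remains open. Also open, on these data alone, is how much of the number rests on the chain itself, since compound 2 and compound 3 each differ from compound 1 in more than one place and give no clean comparison.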